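Shifting a methoxy group on a phenoxyacetyl piperazine

This account rests on a few compounds, and the source may have more. Where it says the series, first, only, none or still open, it means among the compounds named here.

The measured compounds:
- compound 1, `O=C(COc1ccc2ccccc2c1)N1CCN(C(c2ccc(Br)cc2)c2ccc(Br)cc2)CC1`: 7.87%
- compound 2, `COc1ccc(OCC(=O)N2CCN(C(c3ccc(OC)cc3)c3ccc(OC)cc3)CC2)cc1`: 80.7%
- compound 3, `COc1ccc(OCC(=O)N2CCN(C(c3ccc(Br)cc3)c3ccc(Br)cc3)CC2)cc1`: 7.06%

In a functional assay on PC-12 cells (Rattus norvegicus) for cytotoxicity, read by MTT assay, with a stated time of 24 h, tested at 1 uM (on this read-out lower numbers stand for a weaker effect and higher numbers for a stronger effect at the one concentration tested), compound 3 gives the lowest of the three numbers. Compound 1 sits nearest to it, and the two lie within the scatter of each other, as the step of a number 0.8 percentage points lower from compound 1 to compound 3 (within the scatter) shows. Compound 2 stands furthest away, well beyond the scatter, but it differs from compound 3 in more than one place, so its two values show only that the other pattern of groups gives a much higher number.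

Compound 4, `COc1ccccc1OCC(=O)N1CCN(C(c2ccc(Br)cc2)c2ccc(Br)cc2)CC1`, has not yet been measured. Its change from compound 3 is 2-methoxyphenyl in place of 4-methoxyphenyl on an oxygen on a saturated carbon.

Among the compounds with values here, no measured step moves the methoxy group around this ring, so nothing among the measured compounds bears on this change directly. Within the data shown here, the only step with a single change, a number 0.8 percentage points lower from compound 1 to compound 3 (within the scatter), swaps the whole ring on that oxygen and leaves the number within the scatter, which suggests that this part of the molecule has little effect on this read-out among the compounds so far. A step of a number 2.9 percentage points higher from compound 3 to compound 4 (within the scatter) is therefore expected, which is none beyond the scatter. Compound 4 is expected to give 10%, within 3% to 28%.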

Compound 4, a percentage reported as activity, at one concentration (the size of the read-out at that concentration, not a potency): 12.8%
Beside the measured number, compound 4's estimate is 2.8 percentage points below it, and the stated range covers the measured number.
By their numbers in this assay, from the lowest: compounds 3, 1 and 4 (each within the scatter of the next); then compound 2.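

Within the data shown here, the methoxy group can now be followed around the ring for the first time: 2-methoxyphenyl in place of 4-methoxyphenyl gives a number 5.7 percentage points higher from compound 3 to compound 4 (within the scatter) in this assay, so this shift of one group on the same ring leaves no readable difference. A wider swap at the same place tells the same story, with 2-methoxyphenyl in place of naphthalen-2-yl giving a number 4.9 percentage points higher from compound 1 to compound 4 (within the scatter), and so three different groups on that oxygen, compounds 1, 3 and 4, cannot be told apart on this read-out while the rest of the molecule stays the same. No measurement shown here offers an explanation for this lack of difference.

As far as these compounds go, all three of these groups are uncharged aromatic rings carrying only carbon and oxygen, so it remains open whether an amine or a carboxylic acid on that ring would also leave the number in the same range. From the compounds shown here alone, it is also open whether moving the methoxy group would matter on the core of compound 2, which carries 4-methoxyphenyl on the oxygen and gives a far higher number than the compounds with bromine.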